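A few compounds are considered here, and "the series" means these few. Any claim that something is new, unique, unknown or untested is made for them only; others in the source may bear on it.

Measured compounds:
Compound 1, `CCCCCCOc1ccc2c(Cl)ccnc2c1`: 2440 nM
Compound 2, `CCCCCCOc1ccc2c(NCCN(C)C)ccnc2c1`: 850 nM

In a functional assay on HCT-116 cells (Homo sapiens) for cytotoxicity, read by MTT assay, with a stated time of 48 h (on this read-out lower numbers stand for stronger inhibition and higher numbers for weaker inhibition), compound 2 holds the lowest of the two numbers shown, the other being compound 1 with 2440 nM. Among the measured compounds shown here, the single measured step is a 2.9-fold lower number from compound 1 to compound 2 (0.46 log units; beyond the scatter), in which (2-(dimethylamino)ethyl)amino replaces chloro on an aromatic carbon.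

Compound 3, `CN(C)CCNc1ccnc2cc(OCc3ccccc3)ccc12`, differs from compound 2 in another part of the molecule: phenyl in place of pentyl on a saturated chain carbon bound to an oxygen on an aromatic ring. Seen one bond further out, hexyloxy becomes benzyloxy. For the measured compounds named here, no measured step touches this position, so the data give no direction for it; the one step above concerns the amino group and does not carry over. A step within the scatter, a 1.1-fold higher number from compound 2 to compound 3 (0.02 log units; within the scatter), is therefore expected. Compound 3 is estimated at 900 nM, with a range from 300 nM to 2700 nM.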

Compound 3, half-maximal inhibitory concentration in the HCT-116 assay: 1980 nM
Estimate against measurement, compound 3: 2.2-fold (0.34 log units) below; low and high end bracket the measured number.
By their numbers in the HCT-116 assay, from the lowest: compound 2; then compounds 3 and 1 (each within the scatter of the next).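

Among the compounds shown here, compound 3 gives the first measured reading at this position, where hexyloxy becomes benzyloxy and a six-membered aromatic ring enters in place of the open chain. In the HCT-116 assay this change gives a 2.3-fold higher number from compound 2 to compound 3 (0.37 log units; beyond the scatter), so the cell read-out does respond to what sits at this position, and here the number moves up with the ring. In a physicochemical assay for solubility (on this read-out higher numbers stand for higher solubility and lower numbers for lower solubility), compound 2 gives > 10000 ug/mL, which is a limit of the assay and not a number. In the physicochemical assay compound 3 gives > 10000 ug/mL, also a limit, and the step between the two cannot be read because both values sit at the same limit: the limit of > 10000 ug/mL in the physicochemical assay, at which 2 of the 2 values shown sit.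

One pair cannot show whether ring or chain length matters more at this position. On these data alone, how a longer chain, a shorter chain such as butyl, or a phenyl ring carrying a fluorine or a methoxy group would read remains open.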